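A few compounds are considered here, and "the series" means these few. Any claim that something is new, unique, unknown or untested is made for them only; others in the source may bear on it.

Measured compounds:
compound 1 `O=[N+]([O-])c1ccc(S(=O)(=O)N2CC(n3cnc4ncnc(O)c43)OCc3ccccc32)cc1` — > 100000 nM
compound 2 `O=c1cc[nH]c(=O)n1C1CN(S(=O)(=O)c2ccccc2[N+](=O)[O-])c2ccccc2CO1` — 50900 nM
compound 3 `O=[N+]([O-])c1ccc(S(=O)(=O)N2CC(n3cnc4ncnc(Sc5ccccc5)c43)OCc3ccccc32)cc1` — 860 nM

In a functional assay on MCF7 cells (Homo sapiens) for antiproliferative activity (on this read-out higher numbers stand for weaker inhibition and lower numbers for stronger inhibition), compound 1 gives > 100000 nM, which is a limit of the assay rather than a number. In this assay compound 2 gives 50900 nM and stands highest of the two numbers reported, with compound 3 nearest to it at 860 nM. Within the data shown here, the only step between measured compounds that differ in one place is an at least 110-fold lower number from compound 1 to compound 3 (2.06 log units; beyond the scatter), a large change brought about by swapping the group on an aromatic carbon of the shared core, and it rests on a value at the limit of > 100000 nM in this assay, at which 1 of the 3 values shown sits.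

Compound 4 `O=[N+]([O-])c1ccccc1S(=O)(=O)N1CC(n2cnc3ncnc(Cl)c32)OCc2ccccc21` has not yet been measured in this assay. It differs from compound 2 by a group of 10 heavy atoms (5 carbon, 4 nitrogen, 1 chlorine; one five-membered aromatic ring with 2 hetero atoms, one six-membered aromatic ring with 2 hetero atoms) in place of a group of 8 heavy atoms (4 carbon, 2 nitrogen, 2 oxygen; one six-membered aromatic ring with 2 hetero atoms), on a saturated ring carbon. Among the measured compounds shown here, no measured step covers this exchange directly; the closest evidence is the step from compound 1 to compound 3, which shows that the group on the six-membered aromatic ring of the entering fragment can move the number a great deal. Chlorine at that place in compound 4 is untested, so the expectation is uncertain and wide. On balance compound 4 is expected to give a lower number than compound 2, a step estimated at a 10-fold lower number from compound 2 to compound 4 (1.01 log units; beyond the scatter). The estimate for compound 4 in this assay is 5000 nM, within a range from 800 nM to 30000 nM.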

Compound 4, half-maximal inhibitory concentration: 920 nM
For compound 4 the middle estimate is 5.4-fold (0.74 log units) above the measured one; low and high end bracket the measured number.
By their numbers in this assay, from the lowest: compounds 3 and 4 (each within the scatter of the next); then compound 2. At a limit, above all of these: compound 1.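

In this assay, the exchange on the saturated ring carbon next to the ring oxygen gives a 55-fold lower number from compound 2 to compound 4 (1.74 log units; beyond the scatter), while the rest of the molecule stays the same. Among these compounds, the earlier step changed only one group on an aromatic carbon, whereas this one shows that the whole group on the saturated ring carbon also matters greatly, and that a large drop in the number can occur with a chlorine-bearing group of two fused aromatic rings there. Among the compounds shown here, the values shown do not explain why the number falls, and the single exchange does not separate the part played by the ring system from that played by the chlorine.

Still open, as far as these compounds go, is how the number would respond if an amine, a methoxy group or a thioether took the place of the chlorine on this same molecule, and whether the ring system with only a hydrogen there would keep the lower number. Also open, from the compounds shown here alone, is what would follow from replacing the nitro group on the sulfonyl-bearing ring with a nitrile or an amine while the group on the saturated ring carbon stays the same.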